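This account rests on a few compounds, and the source may have more. Where it says the series, first, only, none or still open, it means among the compounds named here.

Within the data shown here, compound 2 `COc1cc(N)c(Cl)cc1C(=O)CCC1CCN(CCNS(=O)(=O)c2ccc(N)cc2)CC1` gives the lowest of the two numbers so far in an assay on brain for displacement of a labelled ligand from 5-hydroxytryptamine receptor 4 (Cavia porcellus), with a stated time of 30 min, in the presence of a further agent that is not named here (on this read-out higher numbers stand for weaker inhibition and lower numbers for stronger inhibition), namely 1.97 nM. Among the measured compounds shown here, its nearest neighbour, compound 1 `COc1cc(N)c(Cl)cc1C(=O)CCC1CCN(CCNS(=O)(=O)c2ccc(C)cc2)CC1`, gives 18 nM in this assay, and the only step measured, a 9.1-fold lower number from compound 1 to compound 2 (0.96 log units; beyond the scatter), is amino in place of methyl on an aromatic carbon. Compound 3 `COc1cc(N)c(Cl)cc1C(=O)CCC1CCN(CCNS(=O)(=O)c2ccc(NC(C)=O)cc2)CC1` carries acetyl in place of hydrogen on a nitrogen on an aromatic ring, reading amino to acetamido on the 4-aminophenyl. For the measured compounds named here, no measured step covers acylation of that nitrogen, so the expected change is uncertain; a modest loss is estimated, a 3.0-fold higher number from compound 2 to compound 3 (0.48 log units; beyond the scatter). Compound 3 is therefore expected near 6 nM, within 1.5 nM to 25 nM.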

Compound 3, inhibition constant: 7.7 nM
Compound 3: the middle estimate sits 1.3-fold (0.11 log units) below what was measured; the range from low to high includes it.
By their numbers in this assay, from the lowest: compound 2; then compound 3; then compound 1.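

Acylating the nitrogen gives back only part of what the amino group gained in this assay (a 3.9-fold higher number from compound 2 to compound 3 (0.59 log units; beyond the scatter)), and the acetamido group still keeps an edge over methyl (a 2.3-fold lower number from compound 1 to compound 3 (0.37 log units; beyond the scatter)). This position therefore accepts an acetyl on the nitrogen, while the free amino group gives the lowest number of the three groups shown, with both of its steps beyond the scatter. Nothing given here explains this order. Still open, going by these compounds, is whether a longer acyl chain such as butanoyl or a benzoyl group on the same nitrogen would follow acetyl, and whether a hydroxyl group in place of the amino group would match compound 2.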